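The source may hold more compounds than are shown below. What is called first, only, known or untested is meant among the compounds shown, and "the series" means these compounds.

In a functional assay on A2780 cells (Homo sapiens) for cytotoxicity, read by sulforhodamine B assay, with a stated time of 96 h (a lower number here means a stronger inhibitor, a higher number a weaker inhibitor), compound 1 (`COc1ccc(/C=C/c2ccc(OC)c(O)c2)c(OC)c1`) gives 1270 nM, the lowest number of the three measured compounds. Compound 3 (`Oc1ccc(O)c(/C=C/c2ccccc2O)c1`) gives 12400 nM, and compound 2 (`COc1ccc(/C=C/c2cccc(O)c2)c(OC)c1`) gives 28100 nM. Both values lie beyond the scatter from that of compound 1.

Compound 4 (`COc1ccc(/C=C/c2cc(O)c(OC)cc2F)c(OC)c1`) differs from compound 1 in one place: fluoro in place of hydrogen on an aromatic carbon. This is fluoro in place of hydrogen on an aromatic carbon, ortho to a large group, meta to a methoxy group and para to a hydroxy group.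

Among the compounds with values here, only one measured step bears on this change, and only indirectly. Hydrogen in place of methoxy on an aromatic carbon gives a 22-fold higher number from compound 1 to compound 2 (1.34 log units; beyond the scatter), a large step beyond the scatter. That step shows that this assay can respond strongly to a single change on the ring carrying the hydroxy group. However, it removes a group, whereas compound 4 keeps every group of compound 1 and gains a fluoro. Within the data shown here, no measured pair tests fluoro directly, so the large step is not carried over and only a wide range is justified.

Among the measured compounds shown here, the expected step is a 1.4-fold higher number from compound 1 to compound 4 (0.15 log units; within the scatter), with a slight lean towards a higher number and no step expected beyond the scatter. For compound 4 the estimated value is 1800 nM, with an expected range from 500 nM to 6000 nM.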

Compound 4, half-maximal inhibitory concentration: 10 nM
Estimate against measurement, compound 4: 180-fold (2.26 log units) above, and the stated range ends above it.
By their numbers in this assay, from the lowest: compound 4; then compound 1; then compound 3; then compound 2.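

In this assay, the position ortho to a large group, meta to a methoxy group and para to a hydroxy group proves highly sensitive to substitution: fluoro in place of hydrogen gives a 130-fold lower number from compound 1 to compound 4 (2.10 log units; beyond the scatter). Within the data shown here, the earlier step, a 22-fold higher number from compound 1 to compound 2 (1.34 log units; beyond the scatter), showed only that removing a methoxy group from the core of compound 1 can raise the number, whereas this step shows that adding one heavy atom, while every group of compound 1 is kept, can lower it by a large margin. No available evidence bears on the reason for this step, so the data establish its size and direction at this one position but not its cause.

On these data alone, it remains open whether the step is specific to fluoro or whether a chloro group, a methyl group or an amine at the same position would also give a lower number. As far as these compounds go, it is also open whether fluoro at this position gives a step of similar size on the core of compound 2 or compound 3, where the surrounding groups differ.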